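The source may report more compounds than this note shows. Statements on the series, on what has been measured and on what is new or still open speak of the compounds shown alone.

Measured compounds:
Compound 1 `N#Cc1ccccc1Nc1sc(C(=O)c2ccc(Br)s2)c(N)c1C#N` – in an assay for inhibition of Maternal embryonic leucine zipper kinase (Homo sapiens), read by ADP-Glo, with a stated time of 0.5 h (on this read-out lower numbers stand for stronger inhibition and higher numbers for weaker inhibition), compound 1 gives > 5000 nM; this is a limit of the assay, not a number.
Compound 2 `N#Cc1c(NCCO)sc(C(=O)c2ccc(Br)s2)c1N` – in this assay compound 2 gives 313 nM.

Among the measured compounds shown here, compound 2 holds the only real number here; the other value sits at the limit of > 5000 nM in this assay, at which 1 of the 2 values shown sits. For the measured compounds named here, the single measured step is an at least 15-fold lower number from compound 1 to compound 2 (1.20 log units; beyond the scatter), a large gain when a whole aromatic group on the ring nitrogen gives way to a short chain.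

Compound 3 `N#Cc1c(NCC(N)=O)sc(C(=O)c2ccc(Br)s2)c1N` differs from compound 2 by carbamoyl in place of hydroxymethyl on a saturated chain carbon bound to a nitrogen on an aromatic ring. The chain on the ring nitrogen stays; only its end group is exchanged, and the two end groups carry the same count of hydrogen-bond donors and acceptors, with one heavy atom added. The measured step replaced a bulky aromatic group with a small chain, so it speaks to a far bigger change than this one and gives little guidance on swapping one small polar end for another.

For compound 3 a step within the scatter is therefore expected, a 1.3-fold higher number from compound 2 to compound 3 (0.11 log units; within the scatter). Compound 3 is estimated at 400 nM, with a range from 150 nM to 1200 nM.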

Compound 3, half-maximal inhibitory concentration: 540 nM
Beside the measured number, compound 3's estimate is 1.4-fold (0.13 log units) below it; low and high end bracket the measured number.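

Swapping the hydroxymethyl end of the chain for carbamoyl gives a 1.7-fold higher number from compound 2 to compound 3 (0.24 log units; within the scatter), so in this assay these two small chain ends cannot be told apart. A second chain also keeps the advantage over the aromatic group: carbamoylmethyl in place of 2-cyanophenyl on the nitrogen gives an at least 9.2-fold lower number from compound 1 to compound 3 (0.96 log units; beyond the scatter), which shows that the gain seen earlier does not belong to 2-hydroxyethyl alone. That step can be read only as a bound, since the value of compound 1 is a limit of the assay and not a number: the limit of > 5000 nM in this assay, at which 1 of the 3 values shown sits.

The compounds shown leave open how far this tolerance reaches, as an amine or a carboxylic acid at the end of the chain, or a longer chain on the same nitrogen, might not behave like these two ends. They also cannot separate the part played by the aromatic ring of 2-cyanophenyl from that of its nitrile, a question that a plain phenyl group on this nitrogen would address.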